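A Hydroxy Group in Place of a Chain Methyl

This account rests on a few compounds, and the source may have more. Where it says the series, first, only, none or still open, it means among the compounds named here.

Of the compounds shown here, three sharing one core have been measured in an ADME assay on PC-3 cells (Homo sapiens) for cytotoxicity, read by sulforhodamine B assay, with a stated time of 48 h, tested at 10 uM; a higher number here means more inhibition at the concentration tested (going by the name of the read-out), a lower number less inhibition. Compound 1, `COc1nc2ccc(Br)cc2cc1C(c1ccccc1)n1cc(-c2ccccc2)nn1`, gives 5.97%. Compound 2, `CCCCc1cn(C(c2ccccc2)c2cc3cc(Br)ccc3nc2OC)nn1`, gives 5.54%, and compound 3, `CCCCCCCCc1cn(C(c2ccccc2)c2cc3cc(Br)ccc3nc2OC)nn1`, gives 2.27%. On these numbers compound 2 stands second highest of the three, with compound 1 nearest and compound 3 furthest, yet both gaps are within the scatter: a number 0.4 percentage points lower from compound 1 to compound 2 (within the scatter) and a number 3.3 percentage points lower from compound 2 to compound 3 (within the scatter). The remaining comparison, a number 3.7 percentage points lower from compound 1 to compound 3 (within the scatter), is also within the scatter, so the three readings are effectively the same.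

Compound 4, `COc1nc2ccc(Br)cc2cc1C(c1ccccc1)n1cc(CCCO)nn1`, differs from compound 2 by hydroxy in place of methyl on a saturated chain carbon, three bonds along the chain from an aromatic carbon. Going by the values given here, none of the measured steps alters the end of a chain in this way. The nearest in kind is the lengthening of the chain, a number 3.3 percentage points lower from compound 2 to compound 3 (within the scatter), which stayed within the scatter, as did the exchanges of the whole group at that position, a number 0.4 percentage points lower from compound 1 to compound 2 (within the scatter) and a number 3.7 percentage points lower from compound 1 to compound 3 (within the scatter). With every measured change leaving this assay flat, no step beyond the scatter is expected from the hydroxy group either, and the estimated step is a number 0.5 percentage points lower from compound 2 to compound 4 (within the scatter). Compound 4 is therefore expected to give about 5% in this assay, with a range from -3% to 14%.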

Compound 4, a percentage reported as inhibition, at one concentration (the size of the read-out at that concentration, not a potency): 14.7%
Compound 4: the middle estimate sits 9.7 percentage points below what was measured, and the stated range ends below it.
By their numbers in this assay, from the lowest: compounds 3, 2, 1 and 4 (each within the scatter of the next, the first and the last beyond it).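

In this assay, the only step shown so far that lies beyond the scatter is a number 12.4 percentage points higher from compound 3 to compound 4 (beyond the scatter), a modest one that sets a 3-hydroxypropyl chain against an octyl chain at this position. The closer change, butyl to 3-hydroxypropyl, gives a number 9.2 percentage points higher from compound 2 to compound 4 (within the scatter), and the exchange of phenyl for 3-hydroxypropyl gives a number 8.7 percentage points higher from compound 1 to compound 4 (within the scatter), so neither can be told apart from no change. This position therefore accepts a hydroxy group at the chain end with no drop in the read-out, while a clear gap appears only against the longest chain shown, and the hydroxy change alone is not shown to shift the number. Nothing available explains that single clear step. A plain propyl chain would separate the effect of the hydroxy group from that of chain length, since the chains compared here differ in both. On these data alone, whether an amine or a carboxylic acid at the end of the chain would behave like the hydroxy group also remains open.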